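A few compounds are considered here, and "the series" means these few. Any claim that something is new, unique, unknown or untested is made for them only; others in the source may bear on it.

Values in a functional assay on K562 cells (Homo sapiens) for inhibition (a lower number here means a stronger inhibitor, a higher number a weaker inhibitor), so far:
compound 1 `CCOc1ccc(Br)cc1-c1cc(Nc2ccc(B(O)O)cc2)nc(N)n1` gives 200 nM
compound 2 `CCOc1ccc(Br)cc1-c1cc(Nc2ccc(C#N)cc2)nc(N)n1` gives 70 nM
compound 3 `CCOc1ccc(Br)cc1-c1cc(Nc2ccc(C(C)=O)cc2)nc(N)n1` gives 50 nM

Compound 3 stands level with compound 2, as a 1.4-fold lower number from compound 2 to compound 3 (0.15 log units; within the scatter) stays within the scatter. Compound 3 is clearly separated from compound 1 by a 4.0-fold lower number from compound 1 to compound 3 (0.60 log units; beyond the scatter), which lies beyond it.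

Compound 4 `CCOc1ccc(Br)cc1-c1cc(Nc2ccc(/C(C)=N\O)cc2)nc(N)n1` carries one change from compound 3, on an aromatic carbon of a six-membered aromatic ring of carbon only, para to a large group: a group of 4 heavy atoms (2 carbon, 1 nitrogen, 1 oxygen; no ring) in place of a group of 3 heavy atoms (2 carbon, 1 oxygen; no ring), on an aromatic carbon.

Within the data shown here, no measured step makes this exact change. The nearest evidence comes from the three steps at the same place, namely a 2.9-fold lower number from compound 1 to compound 2 (0.46 log units; beyond the scatter), a 4.0-fold lower number from compound 1 to compound 3 (0.60 log units; beyond the scatter) and a 1.4-fold lower number from compound 2 to compound 3 (0.15 log units; within the scatter). The largest of these is modest, so this assay has so far shown little response to changes there. Three groups are a thin basis, and they do not fix a direction. The group that stands apart from the other two, in compound 1, lies on the higher side, so the expectation leans slightly that way, with a step near the scatter.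

The expected change is a 1.6-fold higher number from compound 3 to compound 4 (0.20 log units; within the scatter).

For compound 4 the estimate is 80 nM, with an expected range of 25 nM to 250 nM.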

Compound 4, half-maximal inhibitory concentration: < 50 nM
Compound 4: no number, only a limit; the forecaster's own chance of this, stated with the estimate: 2%; middle value at least 1.6-fold (0.20 log units) from the limit.
By their numbers in this assay, from the lowest: compounds 3 and 2 (each within the scatter of the next); then compound 1.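

In this assay compound 4 is recorded only as a limit, < 50 nM. The record shows a number no higher from compound 3 to compound 4 (the limit leaves the size open), so the group of 4 heavy atoms, the largest shown at this position on the aromatic ring, brings no rise over acetyl. Against the other two groups the picture is split: an at least 1.4-fold lower number from compound 2 to compound 4 (0.14 log units; that floor lies within the scatter) gives a floor that does not separate compound 4 from the nitrile, while an at least 4.0-fold lower number from compound 1 to compound 4 (0.60 log units; beyond the scatter) places compound 4 clearly apart from the boronic acid, so that compound 1 remains the only one of the four set apart from the rest. The reading now stops at the edge of what the assay reports, and this limit, not the chemistry, sets how much can be said: the limit of < 50 nM in this assay, at which 1 of the 4 values shown sits.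

On these data alone, how far compound 4 lies past that limit stays unknown, and with it whether this group truly improves on acetyl or merely matches it. As far as these compounds go, whether an amine, a carboxylic acid or a longer chain at this position would hold the same level remains open, as does any change on the shared core away from this ring.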